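A few compounds are considered here, and "the series" means these few. Any claim that something is new, unique, unknown or untested is made for them only; others in the source may bear on it.

Compound 1 `CCC(C)C(NC(=O)n1nnc2ccccc21)C(=O)NC1CCCCC1` was tested in a functional assay on CCRF-CEM cells (Homo sapiens) for inhibition (on this read-out higher numbers stand for weaker inhibition and lower numbers for stronger inhibition), where compound 1 gives 107000 nM. A second compound from the same study, compound 2 `CCC(C)C(NC(=O)NO)C(=O)NC1CCCCC1`, was run in the same way, and in this assay compound 2 gives 153000 nM. The two figures lie within the usual scatter of each other, so on this read-out compound 1 and compound 2 cannot be told apart, and both sit at very weak inhibition.

Going by the values given here, no pair of measured compounds differing in a single place is available, so the move to compound 3 `CCC(C)C(NC(=O)n1nnc2ccccc21)C(=O)NC1CCCC1` must be judged from the structural change alone: cyclopentyl in place of cyclohexyl on an amide-type nitrogen. The change brings no new donor, acceptor or charge, and nothing in the measured pair speaks to a ring of this kind. Among the compounds with values here, with no measured step to lean on, no shift beyond the scatter is expected in either direction, and the step in this assay is estimated at a 1.1-fold higher number from compound 1 to compound 3 (0.05 log units; within the scatter). Compound 3 is therefore expected to give 120000 nM in this assay, within a range from 50000 nM to 300000 nM.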

Compound 3, half-maximal inhibitory concentration: 116000 nM
For compound 3 the middle estimate is 1.0-fold (0.01 log units) above the measured one, within the range that was stated.
By their numbers in this assay, from the lowest: compounds 1, 3 and 2 (each within the scatter of the next).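

With cyclopentyl in place of cyclohexyl on an amide-type nitrogen, this assay shows a 1.1-fold higher number from compound 1 to compound 3 (0.04 log units; within the scatter) and nothing more, so this first comparison at a single place cannot tell the two rings apart. At this position, then, a five-membered carbon ring and a six-membered carbon ring read the same, and the shorter ring leaves inhibition as very weak as it was. No measurement bears on why the two rings read alike.

The compounds shown cover only these two rings of carbon at this nitrogen, so it stays open whether an open alkyl chain, a phenyl ring, or an amine or a carboxylic acid carried on the cyclohexyl would shift the number beyond the scatter. It is equally open whether cyclopentyl would read the same when the rest of the molecule is that of compound 2, since the shown comparison of the rings rests on the core of compound 1 alone.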